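From Ethyl to Methoxy: Expecting Compound 4

The compounds below may be only part of what the source reports. "The series", "measured", "known", "first", "only" and "open" are said of these compounds alone.

Measured so far in a functional assay on Hep 3B2 cells (Homo sapiens) for antiproliferative activity, read by MTT assay, with a stated time of 24 h, tested at 0.41 ug/mL; a higher number here means a stronger effect of the compound at the concentration tested, a lower number a weaker effect:
Compound 1, `CCc1ccc2nc(C(=O)Nc3c(F)cc(-c4cccc(F)c4)cc3F)c(C)c(O)c2c1`, gives 16.2%.
Compound 2, `Cc1c(C(=O)Nc2c(F)cc(-c3cccc(F)c3)cc2F)nc2ccc(OC(F)(F)F)cc2c1O`, gives 5.62%.
Compound 3, `CCc1ccc2nc(C(=O)Nc3c(F)cc(-c4cccc(F)c4)cc3F)c(C)c(C(=O)O)c2c1`, gives 1.68%.

Compound 3 holds the smallest of these three numbers; its gap to compound 2 is within the usual scatter, while a number 14.5 percentage points lower from compound 1 to compound 3 (beyond the scatter) lies beyond it. Compound 4, `COc1ccc2nc(C(=O)Nc3c(F)cc(-c4cccc(F)c4)cc3F)c(C)c(C(=O)O)c2c1`, differs from compound 3 by methoxy in place of ethyl on an aromatic carbon. Within the data shown here, the only measured step at this same place is a number 10.6 percentage points lower from compound 1 to compound 2 (beyond the scatter), a modest lowering, and a number 14.5 percentage points lower from compound 1 to compound 3 (beyond the scatter) touches another place. Since compound 3 already sits near the bottom of the scale in this assay, little room remains for a further fall, so no change beyond the scatter is expected: compound 4 is estimated at 3%, between -7% and 13%, a step of a number 1.3 percentage points higher from compound 3 to compound 4 (within the scatter).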

Compound 4, a percentage reported as inhibition, at one concentration (the size of the read-out at that concentration, not a potency): 0.68%
The estimate for compound 4 lay 2.3 percentage points above the measured number; measured number inside the range.
By their numbers in this assay, from the lowest: compounds 4, 3 and 2 (each within the scatter of the next); then compound 1.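

With the carboxy group in place, methoxy in place of ethyl on this aromatic carbon gives a number 1 percentage points lower from compound 3 to compound 4 (within the scatter) in this assay. Here, then, exchanging these two small groups produces no change that can be told from scatter, although both numbers sit so near the bottom of the scale that a further fall could hardly show. No available evidence explains this result. Still open, going by these compounds, is what methoxy would do on compound 1, which carries hydroxy instead of carboxy, and whether an amine or a longer chain here would raise the number.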